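A few compounds are considered here, and "the series" means these few. Any claim that something is new, unique, unknown or untested is made for them only; others in the source may bear on it.

Compound 1 `CC#Cc1ccc(-c2ccc(C(CO)OC)s2)s1`: 30900 nM
Compound 2 `CC#Cc1ccc(-c2ccc(C=O)s2)s1`: > 100000 nM

Both values come from a functional assay on RAW264.7 cells (Mus musculus), read by colorimetric assay, with a stated time of 24 h, in the presence of a further agent that is not named here; a higher number here means a weaker inhibitor, a lower number a stronger inhibitor. Compound 2 stands at > 100000 nM, which is a limit of the assay and not a number. Compound 3 `CC#Cc1ccc(-c2ccc(C(=O)OC)s2)s1` is still unmeasured and differs from compound 2 by methoxy in place of hydrogen on a carbonyl carbon, or formyl to methoxycarbonyl. Within the data shown here, one measured step bears on this change, at the same carbon of the shared core: an at least 3.2-fold higher number from compound 1 to compound 2 (0.51 log units; beyond the scatter), where formyl replaced 2-hydroxy-1-methoxyethyl. On these data alone, this single step gives weak guidance, and its full size is unknown. Moving away from formyl, a modest change towards a lower number is expected, an at least 1.6-fold lower number from compound 2 to compound 3 (0.22 log units; that floor lies within the scatter). A result at the limit also remains possible. For compound 3 the estimated value is 60000 nM, with an expected range from 20000 nM to 100000 nM.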

Compound 3, half-maximal inhibitory concentration: > 100000 nM
Compound 3 ended at the assay's limit (the forecaster's own chance of this, stated with the estimate: 40%); middle value at least 1.6-fold (0.22 log units) away from the limit.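

In this assay, methoxycarbonyl in place of 2-hydroxy-1-methoxyethyl on this aromatic carbon gives an at least 3.2-fold higher number from compound 1 to compound 3 (0.51 log units; beyond the scatter), so a second carbonyl-containing group now joins formyl on the weaker side of compound 1. The step between formyl and methoxycarbonyl cannot be read: both values are limits of the assay, and no order between compound 2 and compound 3 follows from them. Adding methoxy to the carbonyl carbon therefore brings no readable gain, and the series holds one measured number, that of compound 1: the limit of > 100000 nM in this assay, at which 2 of the 3 values shown sit.

On these data alone, whether a carboxylic acid or an amine on this aromatic carbon would return the number towards compound 1 at 30900 nM stays open. Also open, as far as these compounds go, is whether the hydroxy or the methoxy of 2-hydroxy-1-methoxyethyl matters more, and whether a longer chain would do better.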